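Lengthening the Ether Chain: From Allyl to Pentyl

The source may hold more compounds than are shown below. What is called first, only, known or untested is meant among the compounds shown, and "the series" means these compounds.

Three measured compounds share one core and differ only in the group on a saturated chain carbon bound to an oxygen on an aromatic ring. In a functional assay on J774.A1 cells (Mus musculus) for inhibition, read by immunoassay, with a stated time of 12 h, tested at 30 uM (on this read-out lower numbers stand for less inhibition and higher numbers for more inhibition at the one concentration tested (going by the name of the read-out)), compound 1 `O=C1CC(c2ccccc2OCc2ccccc2)Oc2ccccc21` gives 91.5%. Compound 2 `C=CCOc1ccccc1C1CC(=O)c2ccccc2O1` gives 47%, and compound 3 `CCCCOc1ccccc1C1CC(=O)c2ccccc2O1` gives 42.5%. On these numbers compound 2 stands second highest of the three: the drop a number 44.5 percentage points lower from compound 1 to compound 2 (beyond the scatter) lies beyond the scatter, whereas the gap a number 4.5 percentage points lower from compound 2 to compound 3 (within the scatter) does not. Compound 4 `CCCCCOc1ccccc1C1CC(=O)c2ccccc2O1` has not yet been measured in this assay; it differs from compound 2 by butyl in place of vinyl on a saturated chain carbon bound to an oxygen on an aromatic ring. The step that bears most directly on this change is a number 4.5 percentage points lower from compound 2 to compound 3 (within the scatter), where a saturated chain also took the place of the vinyl and the number barely moved. The two large steps, a number 44.5 percentage points lower from compound 1 to compound 2 (beyond the scatter) and a number 49 percentage points lower from compound 1 to compound 3 (beyond the scatter), concern the loss of a phenyl and do not apply here. Compound 4 is therefore expected to show a step of a number 5 percentage points lower from compound 2 to compound 4 (within the scatter), staying within the scatter. The estimate for compound 4 is 42%, with a range from 25% to 60%.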

Compound 4, a percentage reported as inhibition, at one concentration (the size of the read-out at that concentration, not a potency): 40.1%
Compound 4: the middle estimate sits 1.9 percentage points above what was measured; the measured number falls inside the stated range.
By their numbers in this assay, from the lowest: compounds 4, 3 and 2 (each within the scatter of the next); then compound 1.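

Adding a methyl on a saturated chain carbon, four bonds along the chain from an oxygen on an aromatic ring, gives a number 2.4 percentage points lower from compound 3 to compound 4 (within the scatter) in this assay and butyl in place of vinyl gives a number 6.9 percentage points lower from compound 2 to compound 4 (within the scatter) so neither the extra chain length nor the lost double bond shows up in this read-out. Phenyl alone stands apart: butyl in its place gives a number 51.4 percentage points lower from compound 1 to compound 4 (beyond the scatter) as a third group without a ring that sits far lower. Nothing in the data given accounts for these numbers.

From the compounds shown here alone, whether a longer chain such as octyl, or a chain ending in an amine or a carboxylic acid, would move the number stays open. So does whether a ring other than phenyl, such as cyclohexyl, would bring the number back towards that of compound 1.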